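This account rests on a few compounds, and the source may have more. Where it says the series, first, only, none or still open, it means among the compounds named here.

Values in a functional assay on MV4-11 cells (Homo sapiens) for antiproliferative activity, read by resazurin assay, with a stated time of 72 h (a higher number here means a weaker inhibitor of growth, a lower number a stronger inhibitor of growth), follow.
- compound 1 `CN1CCN(c2cccc(Nc3nccc(-c4c[nH]c5cccnc45)n3)c2)CC1` gives 405 nM
- compound 2 `CC(=O)N1CCCN(c2cccc(Nc3nccc(-c4cnc5n(C)cccc4-5)n3)c2)CC1` gives 24 nM

Compound 2 has the lower number of the two, and the gap to compound 1 lies beyond the scatter. Compound 3 `CC(=O)N1CCCN(c2cccc(Nc3nccc(-c4c[nH]c5cccnc45)n3)c2)CC1` is still unmeasured. The change a group of 9 heavy atoms (7 carbon, 2 nitrogen; one five-membered aromatic ring with 1 hetero atom, one six-membered aromatic ring with 1 hetero atom) in place of a group of 10 heavy atoms (8 carbon, 2 nitrogen; one five-membered aromatic ring with 1 hetero atom, one six-membered aromatic ring with 1 hetero atom), on an aromatic carbon sits on an aromatic carbon of a six-membered aromatic ring with 2 nitrogen. Within the data shown here, the entering group is also carried by compound 1 (405 nM), but compound 1 differs from compound 2 elsewhere too, so no measured pair isolates this change. The expected 5.0-fold higher number from compound 2 to compound 3 (0.70 log units; beyond the scatter) points to a weaker inhibitor of growth, beyond the scatter. The estimate for compound 3 is 120 nM (range 35 nM to 420 nM).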

Compound 3, concentration for 50% growth inhibition: 688 nM
Compound 3: the middle estimate sits 5.7-fold (0.76 log units) below what was measured; measured number above the stated range.
By their numbers in this assay, from the lowest: compound 2; then compounds 1 and 3 (each within the scatter of the next).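

In this assay the group on the aromatic carbon of the six-membered aromatic ring with 2 nitrogen now has a step of its own: the group of 9 heavy atoms and 1 hydrogen-bond donor replacing the group of 10 heavy atoms and 0 hydrogen-bond donors gives a 29-fold higher number from compound 2 to compound 3 (1.46 log units; beyond the scatter) on this change alone. Elsewhere, 4-acetyl-1,4-diazepan-1-yl in place of 4-methylpiperazin-1-yl gives a 1.7-fold higher number from compound 1 to compound 3 (0.23 log units; within the scatter) and so does not separate those two compounds. Nothing available bears on the origin of the large step.

The two groups differ in more than one feature, and the compounds shown do not tell which feature carries the step. Also open, from the compounds shown here alone, is whether an ethyl or 2-methoxyethyl group on the ring nitrogen of the entering group would give a number nearer that of compound 2.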